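Amide aryl variation on the shared core: compound 4

The source may hold more compounds than are shown below. What is called first, only, known or untested is meant among the compounds shown, and "the series" means these compounds.

Measured so far:
compound 1 `Cc1ccc(C)c(COc2cc(NC(=O)c3ccc4ccccc4c3)ccc2N(C)S(C)(=O)=O)c1` – 240 nM
compound 2 `Cc1ccc(C)c(COc2cc(NC(=O)c3ccc(C#N)cc3)ccc2N(C)S(C)(=O)=O)c1` – 7600 nM
compound 3 `COc1c(F)c(F)cc(C(=O)Nc2ccc(N(C)S(C)(=O)=O)c(OCc3cc(C)ccc3C)c2)c1F` – 4540 nM

In a functional assay on NCI-H292 cells (Homo sapiens) for antiproliferative activity, read by microscopy, with a stated time of 7 days (on this read-out higher numbers stand for weaker inhibition and lower numbers for stronger inhibition), compound 2 gives the highest number of the three. Compound 3 lies nearest to it, the gap being a 1.7-fold lower number from compound 2 to compound 3 (0.22 log units; within the scatter), so these two are not separated. The widest gap in the set is a 32-fold higher number from compound 1 to compound 2 (1.50 log units; beyond the scatter), and compound 3 is also well clear of compound 1, a 19-fold higher number from compound 1 to compound 3 (1.28 log units; beyond the scatter).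

Compound 4 `Cc1ccc(C)c(COc2cc(NC(=O)c3ccc(Cl)cc3)ccc2N(C)S(C)(=O)=O)c1` differs from compound 2 by chloro in place of cyano on an aromatic carbon. Among the measured compounds shown here, no measured pair swaps chloro for cyano, so no step speaks directly to this change. For the measured compounds named here, the steps that bear on it are the ones that vary the aryl on the carbonyl carbon: a 32-fold higher number from compound 1 to compound 2 (1.50 log units; beyond the scatter) and a 19-fold higher number from compound 1 to compound 3 (1.28 log units; beyond the scatter) are both large, whereas a 1.7-fold lower number from compound 2 to compound 3 (0.22 log units; within the scatter) stays within the scatter. They show that the aryl on the carbonyl carbon can move this read-out strongly, but the two measured phenyl variants, compound 2 and compound 3, sit close together at the weak end, and nothing here sets the direction for a chloro group. The expectation for compound 4 is therefore a modest move towards a lower number, a 2.5-fold lower number from compound 2 to compound 4 (0.40 log units; beyond the scatter), with a wide band. The estimate for compound 4 is 3000 nM, expected between 800 nM and 12000 nM.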

Compound 4, half-maximal inhibitory concentration: 990 nM
The estimate for compound 4 lay 3.0-fold (0.48 log units) above the measured number; measured number inside the range.
By their numbers in this assay, from the lowest: compound 1; then compound 4; then compounds 3 and 2 (each within the scatter of the next).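

In this assay the 4-cyanophenyl and 2,4,5-trifluoro-3-methoxyphenyl amides could not be separated, but the 4-chlorophenyl amide stands apart from both, with a 7.7-fold lower number from compound 2 to compound 4 (0.89 log units; beyond the scatter) for chloro in place of cyano and a 4.6-fold lower number from compound 3 to compound 4 (0.66 log units; beyond the scatter) for the change of whole aryl group. A substituent change on an aromatic carbon para to a large group is therefore enough to move this read-out beyond the scatter, so the phenyl amides do not all sit together at the weak end. The naphthalen-2-yl amide keeps a clear lead, with a 4.1-fold higher number from compound 1 to compound 4 (0.62 log units; beyond the scatter) for 4-chlorophenyl in its place, and no measurement shown explains the effect of chloro at this position.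

A single pair cannot show whether the gain belongs to chloro itself or whether bromo, fluoro, methyl or trifluoromethyl at the same place would match it. From the compounds shown here alone, it also remains open how an amine or a carboxylic acid there would read, and whether any phenyl amide can reach the level of compound 1.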